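A few compounds are considered here, and "the series" means these few. Any claim that something is new, unique, unknown or untested is made for them only; others in the source may bear on it.

Compound 1 `Cc1ccccc1N/C(=N\C#N)NC(NC(=O)CCCc1ccccc1)C(C)(C)C` gives 25.1 nM in a functional assay on HEK293 cells for antagonist activity at P2X purinoceptor 7 (Rattus norvegicus), read by FLIPR and calcium flux; on this read-out lower numbers stand for stronger inhibition and higher numbers for weaker inhibition. Among the three measured compounds it carries the lowest number, yet both others sit within the usual scatter of it: compound 2 `CC(C)(C)C(NC(=O)CCCc1cccnc1)N/C(=N/C#N)Nc1cccc2ncccc12` gives 39.8 nM in this assay and compound 3 `Cc1ncccc1N/C(=N\C#N)NC(NC(=O)CCCCc1ccccc1)C(C)(C)C` gives 50.1 nM. Among the measured compounds shown here, no pair of measured compounds differs in a single place, so no measured step is available to anchor a change on the chain that carries the phenyl ring.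

Compound 4 `COc1ccc(CCC(=O)NC(N/C(=N/C#N)Nc2ccccc2C)C(C)(C)C)cc1OC` differs from compound 1 by 3,4-dimethoxyphenyl in place of benzyl on a saturated chain carbon, two bonds along the chain from a carbonyl carbon. The core and the remaining chain are unchanged. With nothing measured on this part of the series, the expectation is a step in this assay that does not clearly exceed the scatter, if anything a slight drift toward a higher number; the step from compound 1 to compound 4 is estimated as a 1.6-fold higher number from compound 1 to compound 4 (0.20 log units; within the scatter). For compound 4 the expected value in this assay is 40 nM, with a range from 13 nM to 125 nM.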

Compound 4, half-maximal inhibitory concentration: 316 nM
Compound 4: middle estimate off by 7.9-fold (0.90 log units), on the low side; the whole stated range lies below it.
By their numbers in this assay, from the lowest: compounds 1, 2 and 3 (each within the scatter of the next); then compound 4.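

Among the compounds shown here, the place named in the step, on a saturated chain carbon, two bonds along the chain from a carbonyl carbon, does respond to substitution: in this assay the change to 3,4-dimethoxyphenyl gives a 13-fold higher number from compound 1 to compound 4 (1.10 log units; beyond the scatter) and is the only step here beyond the scatter. Cut one bond further out, the same difference reads phenethyl to 3,4-dimethoxybenzyl, so the chain leading to the ring shortens while the ring gains its methoxy groups, and this single step cannot be divided between those two changes. No supporting measurement accounts for the size of this step.

On these data alone, it remains open whether the shorter chain or the methoxy groups carry the step. An unsubstituted phenyl on the shorter chain and 3,4-dimethoxyphenyl on the longer chain would separate them, and a single methoxy group would show whether one substituent is enough.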